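Aryl amide replacing thiazole amide on the piperidine chain

A few compounds are considered here, and "the series" means these few. Any claim that something is new, unique, unknown or untested is made for them only; others in the source may bear on it.

Compound 2 `O=C(NC[C@@H]1C[C@@H]2C=C[C@@H]1C2)NS(=O)(=O)N1CCC(CCNC(=O)c2cscn2)CC1` stands highest of the two numbers in a functional assay on the whole organism (blood) with Rattus norvegicus as the target, with stated times of 24 h and 1 h, at a dose of 15 mg/kg by the intraperitoneal route (on this read-out lower numbers stand for a weaker effect and higher numbers for a stronger effect at the one dose given), where compound 2 gives 37%. Its nearest neighbour, compound 1 `CC(=O)NCCC1CCN(S(=O)(=O)NC(=O)NC[C@@H]2C[C@@H]3C=C[C@@H]2C3)CC1`, gives 25% in this assay. Within the data shown here, the only measured step is a number 12 percentage points higher from compound 1 to compound 2 (beyond the scatter). Compound 3 `COc1ccc(C(=O)NCCC2CCN(S(=O)(=O)NC(=O)NC[C@@H]3C[C@@H]4C=C[C@@H]3C4)CC2)cn1` differs from compound 2 by 6-methoxypyridin-3-yl in place of 1,3-thiazol-4-yl on a carbonyl carbon. Among the measured compounds shown here, the one measured step concerns the same carbonyl carbon but trades methyl for an aromatic ring, so it bears only loosely on an exchange of one aromatic ring for another. A step of a number 3 percentage points higher from compound 2 to compound 3 (within the scatter) is expected, within the scatter. Compound 3 is estimated at 40%, with a range of 22% to 58%.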

Compound 3, a percentage reported as activity, at one dose (the size of the read-out at that dose, not a potency): 32%
The estimate for compound 3 lay 8 percentage points above the measured number; the range from low to high includes it.
By their numbers in this assay, from the lowest: compounds 1, 3 and 2 (each within the scatter of the next, the first and the last beyond it).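

In this assay, one aromatic ring exchanged for another on the carbonyl carbon gives a number 5 percentage points lower from compound 2 to compound 3 (within the scatter), so this position does not separate 1,3-thiazol-4-yl from the larger 6-methoxypyridin-3-yl. An aromatic ring in place of methyl does not always give a step beyond the scatter: the thiazole gives a number 12 percentage points higher from compound 1 to compound 2 (beyond the scatter), whereas compound 3 goes against this with a number 7 percentage points higher from compound 1 to compound 3 (within the scatter). No evidence at hand accounts for these steps.

Still open, on these data alone, is how a plain phenyl ring or an aminomethyl group on this carbonyl carbon would read against methyl and 1,3-thiazol-4-yl.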